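Ethyl for Methyl on a Pyrazole Nitrogen

A few compounds are considered here, and "the series" means these few. Any claim that something is new, unique, unknown or untested is made for them only; others in the source may bear on it.

Within the data shown here, compound 3, `Cn1ccc(-c2ccccc2NCC2=NCCN2)n1`, is the one member of this small set with a proper number: in an in vitro functional assay on cells (Fibroblast) for agonist activity at Alpha-1B adrenergic receptor (Homo sapiens) (a lower number here means that less compound is needed, a higher number that more compound is needed for the effect), compound 3 gives 50.1 nM. Compound 1, `CCn1nccc1-c1ccccc1NCC1=NCCN1`, is recorded in this assay only as a limit, < 100000 nM. Compound 2, `CCCn1nccc1-c1ccccc1NCC1=NCCN1`, likewise sits at a limit in this assay, < 100000 nM. The change between these two, (methyl in place of hydrogen on a saturated chain carbon, two bonds along the chain from an aromatic nitrogen), therefore leaves a step that cannot be read, a step that the two limits leave unreadable from compound 1 to compound 2, since both ends rest on (the limit of < 100000 nM in this assay, at which 2 of the 3 values shown sit). How the core of compound 3 differs from the core of compound 1 is not broken down here.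

Compound 4, `CCn1ccc(-c2ccccc2NCC2=NCCN2)n1`, stands next to compound 3 by the change (methyl in place of hydrogen on a saturated chain carbon bound to an aromatic nitrogen). Among the measured compounds shown here, this is the same kind of change as the one from compound 1 to compound 2, but not the same: there the added carbon sat two bonds along the chain from an aromatic nitrogen, here it sits on a saturated chain carbon bound to an aromatic nitrogen. For the measured compounds named here, nothing among the measured compounds reads out the size of such a step, and the unreadable step from compound 1 to compound 2 offers no guidance either way.

With only the value of compound 3 to rest on, the expected step from compound 3 to compound 4 in this assay is a 1.4-fold higher number from compound 3 to compound 4 (0.15 log units; within the scatter), a small one. The estimate for compound 4 in this assay is 70 nM, expected to fall between 20 nM and 250 nM.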

Compound 4, half-maximal effective concentration: < 100000 nM
Compound 4 was reported as a limit; the forecaster's own chance of this, stated with the estimate: 5%; the middle value is on the limit's open side.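

Compound 4 is recorded in this assay only as a limit, < 100000 nM. The step between compound 3 and compound 4 therefore cannot be read, and no new step size is gained: the limit of < 100000 nM in this assay, at which 3 of the 4 values shown sit. The compounds shown leave open the size of every step in this assay that ends on such a limit, including the change from methyl to ethyl.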